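A ring methyl on compound 2

The source may report more compounds than this note shows. Statements on the series, on what has been measured and on what is new or still open speak of the compounds shown alone.

In an ADME assay on microsomes from liver (Mus musculus) for metabolic stability, read by LC-MS, using NADPH, with stated times of 6 min and 10 min, tested at 0.5 uM (a lower number here means that less of the compound is left, a higher number that more of the compound is left), compound 1 (`COc1ccc(-c2cc(Cl)c3c(N)ncnn23)cc1N1CCN(C(C)=O)C(C)(C)C1=O`) gives 94% and compound 2 (`CC(=O)N1CCN(c2cc(-c3cc(Cl)c4c(N)ncnn34)ccc2C#N)C(=O)C1(C)C`) gives 89%. These two values lie within the scatter of each other, so the numbers do not separate the compounds. Within the data shown here, the only measured step, cyano in place of methoxy on an aromatic carbon, is a number 5 percentage points lower from compound 1 to compound 2 (within the scatter).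

Compound 3 (`CC(=O)N1C[C@H](C)N(c2cc(-c3cc(Cl)c4c(N)ncnn34)ccc2C#N)C(=O)C1(C)C`) carries a different change: methyl in place of hydrogen on a saturated ring carbon. In short, it has methyl in place of hydrogen on a saturated ring carbon. Among the measured compounds shown here, the measured step concerns an aromatic carbon and not this ring, so it offers only weak guidance, and no measured pair tests a change at this place.

Starting from compound 2 at 89%, and with the one measured step within the scatter, no step beyond the scatter is expected in this assay. The estimated step is a number 3 percentage points lower from compound 2 to compound 3 (within the scatter). Compound 3 is expected at 86%, with an estimated range from 72% to 96%. For the measured compounds named here, the range is kept wide on its lower side, as no measurement yet covers a substituent at this ring carbon.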

Compound 3, percent of the compound remaining: 85%
Compound 3: the middle estimate sits 1 percentage points above what was measured; low and high end bracket the measured number.
By their numbers in this assay, from the lowest: compounds 3, 2 and 1 (each within the scatter of the next).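

In this assay, among these compounds, methyl in place of hydrogen on a saturated ring carbon gives a number 4 percentage points lower from compound 2 to compound 3 (within the scatter), and this is the first measured step at this six-membered ring rather than on the aromatic carbon of the earlier pair. The numbers therefore do not separate compound 3 from compound 2, so this ring carbon, next to the ring nitrogen and next to the ring atom that bears a large group, can carry one methyl group with no step beyond the scatter in this read-out of the percent of compound remaining. Nothing available explains this result or shows what the methyl does here.

The compounds shown leave open how a longer chain such as ethyl, a hydroxymethyl group or an amine would read at this ring carbon, and whether the methyl in the opposite spatial arrangement would read the same. They also leave open whether this methyl would give a similar step on compound 1, which carries methoxy where compound 3 carries cyano.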